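Replacing an amino group with nitro on a stilbene sulfone

This account rests on a few compounds, and the source may have more. Where it says the series, first, only, none or still open, it means among the compounds named here.

Measured so far:
Compound 1, `COc1cc(OC)c(/C=C/S(=O)(=O)Cc2ccc(OC)c([N+](=O)[O-])c2)c(OC)c1` — "not determined" (no result reported) in a functional assay on T47D cells (Homo sapiens) for cytotoxicity, read by MTT assay, with a stated time of 72 h; on this read-out lower numbers stand for stronger inhibition of growth and higher numbers for weaker inhibition of growth.
Compound 2, `COc1ccc(CS(=O)(=O)/C=C/c2c(OC)cccc2OC)cc1N` — 50 nM.

Compound 2 carries the only number shown; in this assay compound 2 gives 50 nM, and compound 1 stands without a result, so there is nothing to rank compound 2 against. Compound 3, `COc1ccc(CS(=O)(=O)/C=C/c2c(OC)cccc2OC)cc1[N+](=O)[O-]`, is the next compound to be tested in this assay. It differs from compound 2 in a single place: nitro in place of amino on an aromatic carbon. For the measured compounds named here, no pair of measured compounds shows what this exchange does, so the size of its effect is open. A modest loss of growth inhibition, somewhat beyond the scatter of this assay, is expected for compound 3, which means the step of a 3.0-fold higher number from compound 2 to compound 3 (0.48 log units; beyond the scatter) is the estimated change. Compound 3 is therefore expected to give about 150 nM, within a range from 40 nM to 600 nM.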

Compound 3, concentration for 50% growth inhibition: > 30000 nM
Compound 3 was reported as a limit; the forecaster's own chance of this, stated with the estimate: 5%; at least 200-fold (2.30 log units) between middle value and limit.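

In this assay, swapping the amino group for nitro on this aromatic carbon, ortho to a methoxy group, gives an at least 600-fold higher number from compound 2 to compound 3 (2.77 log units; beyond the scatter), so this one place has a very large say in growth inhibition within this pair. Compound 3 gives > 30000 nM, which is a limit of the assay and not a number. The step is therefore a minimum, and how far compound 3 really lies from compound 2 stays unknown: the limit of > 30000 nM in this assay, at which 1 of the 3 values shown sits.

This single pair cannot separate what losing the amino group does from what gaining the nitro group does, and it gives no reason for the drop. On these data alone, how a hydroxyl group, an acetamide or a methylamino group would behave at this place remains open, as does whether plain hydrogen there would keep the growth inhibition of compound 2.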